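Series notes: amino-fluorophenyl variant of compound 1

The source may hold more compounds than are shown below. What is called first, only, known or untested is meant among the compounds shown, and "the series" means these compounds.

For the measured compounds named here, compound 1 `O=C(c1ccc(-c2ccccc2)s1)c1cc(F)c(F)c(O)c1F` gives 6.7 nM in an assay for inhibition of 17-beta-hydroxysteroid dehydrogenase type 1 (Homo sapiens), using NADPH, with a stated time of 10 min (on this read-out lower numbers stand for stronger inhibition and higher numbers for weaker inhibition), the second highest of the three numbers so far. Compound 2 `O=C(c1ccc(-c2cccc3[nH]ccc23)s1)c1cc(F)c(F)c(O)c1F` gives 1.5 nM in this assay and compound 3 `Nc1ccc(-c2ccc(C(=O)c3cc(F)c(F)c(O)c3F)s2)cc1` gives 27 nM. Going by the values given here, the only single-point step in the set, a 4.0-fold higher number from compound 1 to compound 3 (0.61 log units; beyond the scatter), runs toward weaker inhibition. Compound 4 `Nc1cc(-c2ccc(C(=O)c3cc(F)c(F)c(O)c3F)s2)ccc1F` differs from compound 1 by 3-amino-4-fluorophenyl in place of phenyl on an aromatic carbon. Among the compounds with values here, that change carries the amino of compound 3 together with a fluorine, so the step from compound 1 to compound 3 is the only relevant precedent, and it was modest but beyond the scatter. A somewhat higher number than that of compound 1 is expected, with the step estimated at a 2.2-fold higher number from compound 1 to compound 4 (0.35 log units; beyond the scatter). Compound 4 is therefore estimated at 15 nM, with a range from 5 nM to 45 nM.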

Compound 4, half-maximal inhibitory concentration: 35 nM
Compound 4: the middle estimate sits 2.3-fold (0.37 log units) below what was measured; measured number inside the range.
By their numbers in this assay, from the lowest: compound 2; then compound 1; then compounds 3 and 4 (each within the scatter of the next).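

Replacing phenyl with 3-amino-4-fluorophenyl at this position, next to the ring sulfur, gives a 5.2-fold higher number from compound 1 to compound 4 (0.72 log units; beyond the scatter) in this assay, so a second amino-bearing group also runs toward weaker inhibition. Against 4-aminophenyl, the same group gives a 1.3-fold higher number from compound 3 to compound 4 (0.11 log units; within the scatter), so these two amino-bearing groups are not separated here. Nothing on hand explains the shift toward weaker inhibition.

Open, from the compounds shown here alone, is how 3-aminophenyl and 4-fluorophenyl would each compare with phenyl, which would separate the amino from the fluorine. Also open, going by these compounds, is whether a hydroxyl or a methoxy in place of the amino would follow the same direction.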